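The source may hold more compounds than are shown below. What is called first, only, known or untested is meant among the compounds shown, and "the series" means these compounds.

Of the compounds shown here, two have so far been measured in an ADME assay on MT4 cells (Homo sapiens) for cytotoxicity, read by XTT assay, with a stated time of 5 days; a higher number here means that more compound is tolerated, a lower number that less compound is tolerated. Compound 1, `C=CCNC(=O)[C@@H](NC(=O)[C@](O)(CCCN(Cc1ccc(Br)cc1)NC(=O)[C@@H](NC(=O)OC)C(C)(C)C)Cc1ccc(Br)cc1)C(C)C`, gives 4500 nM in this assay. Compound 2, `COC(=O)N[C@H](C(=O)NN(CCC[C@@]1(O)Cc2ccc(cc2)/C=C\CNC(=O)[C@H](C(C)(C)C)NC1=O)Cc1ccc(Br)cc1)C(C)(C)C`, gives 40000 nM in this assay. Of these two numbers compound 1 is the lower one, a gap to compound 2 that lies beyond the scatter, so compound 1 is the member the cells tolerate less of. The two measured compounds differ in more than one place, so no single structural step can be read directly from their values.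

The new compound, compound 3, `C=CCNC(=O)[C@@H](NC(=O)[C@](O)(CCCN(Cc1ccc(Br)cc1)NC(=O)[C@@H](NC(=O)OC)C(C)(C)C)Cc1ccc(Br)cc1)C(C)(C)C`, is derived from compound 1 by one small change: methyl in place of hydrogen on a saturated chain carbon bound to three saturated chain carbons. The rest of the molecule is kept as in compound 1. A single methyl added at such a position is a small alteration, and the expected step is no change at the digits printed from compound 1 to compound 3 (within the scatter), that is, nothing beyond the scatter in either direction. Compound 3 is therefore estimated at 4500 nM in this assay, with a range from 2000 nM to 10000 nM.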

Compound 3, half-maximal cytotoxic concentration: 21000 nM
Compound 3: the middle estimate sits 4.7-fold (0.67 log units) below what was measured, outside the stated range (above it).
By their numbers in this assay, from the lowest: compound 1; then compounds 3 and 2 (each within the scatter of the next).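

In this assay, the change from isopropyl to tert-butyl gives a 4.7-fold higher number from compound 1 to compound 3 (0.67 log units; beyond the scatter) and is therefore not a silent one: adding a single methyl on a saturated chain carbon bound to three saturated chain carbons lets the cells tolerate more of the compound. The earlier compounds shown here could not show this, since they differ in more than one place, whereas this pair isolates one position with the rest of the molecule kept the same. No measurement shown explains why one added methyl has this effect.

Only isopropyl and tert-butyl are shown at this position, so it remains open whether a plain methyl, a cyclohexyl group, or a chain ending in an amine would continue this trend or break it. The step also rests on a single pair of compounds, which leaves open whether the same change would give a similar step on a different core.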